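This account rests on a few compounds, and the source may have more. Where it says the series, first, only, none or still open, it means among the compounds named here.

In an ADME assay on MRC5 cells (Homo sapiens) for cytotoxicity, read by fluorescence and resazurin assay, with a stated time of 3 days (a higher number here means a weaker inhibitor, a lower number a stronger inhibitor), three analogues of one shared core have been examined so far. Compound 1, `Cc1cn(C2CCN(Cc3cc(Oc4ccccc4)ccn3)CC2)c(=O)[nH]c1=O`, gives > 64000 nM, which is a limit of the assay rather than a number. Compound 2, `Cc1cn(C2CCN(Cc3cccc(Oc4cc(F)cc(F)c4)c3)CC2)c(=O)[nH]c1=O`, gives > 64000 nM, again only a limit. Compound 3, `Cc1cn(C2CCN(Cc3cncc(Oc4cccc(OC(F)(F)F)c4)c3)CC2)c(=O)[nH]c1=O`, gives > 64000 nM, also a limit. Compound 2 therefore stands exactly where every value shown stands: at the limit recorded in the limit of > 64000 nM in this assay, at which 3 of the 3 values shown sit, with no number to set it apart from compound 1 or compound 3. Going by the values given here, no step between measured compounds can be stated, since all three sit at that same limit. The unmeasured compound 4, `Cc1cn(C2CCN(Cc3cccc(Oc4ccc(Cl)c(C(F)(F)F)c4)c3)CC2)c(=O)[nH]c1=O`, is related to compound 2 by a single change: 4-chloro-3-(trifluoromethyl)phenyl in place of 3,5-difluorophenyl on an oxygen on an aromatic ring. With all three measured values at the limit, no direction can be read from them, and the step expected in this assay, a number no higher from compound 2 to compound 4 (the limit leaves the size open), is none beyond the scatter. Compound 4 is thus estimated at 64000 nM in this assay, with a range from 25000 nM to 160000 nM, most probably reported again as a limit only.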

Compound 4, half-maximal inhibitory concentration: 5280 nM
Estimate against measurement, compound 4: 12-fold (1.08 log units) above; the measured number lies below the stated range.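

Among the compounds shown, the aryl group on the oxygen is the one place where a single change moves the read-out in this assay: 4-chloro-3-(trifluoromethyl)phenyl in place of 3,5-difluorophenyl gives an at least 12-fold lower number from compound 2 to compound 4 (1.08 log units; beyond the scatter). Neither group carries a hydrogen-bond donor, a hydrogen-bond acceptor or a net charge, so the step comes with no difference in those counts. The true size of the step stays unknown, since compound 2 is recorded only at a limit: the limit of > 64000 nM in this assay, at which 3 of the 4 values shown sit.

The compounds shown leave open whether the chloro or the trifluoromethyl group accounts for the step, for the two enter together. They also leave open how a nitrile, an amine or a carboxylic acid on that ring would read in this assay.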